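Hydroxy for methyl on an anilino nicotinic ligand

The source may report more compounds than this note shows. Statements on the series, on what has been measured and on what is new or still open speak of the compounds shown alone.

Two compounds share a bicyclic amine attached to an aromatic core that carries an anilino group. Compound 1 `Cc1ccc(Nc2cncc(N3CC4CC(C3)N4)c2)cc1` was tested in an assay on cell membranes for displacement of a labelled ligand from Neuronal acetylcholine receptor; alpha4/beta2 (Rattus norvegicus) (a higher number here means a weaker inhibitor, a lower number a stronger inhibitor), where compound 1 gives 0.148 nM. Compound 2 `c1ccc(Nc2ccc(N3CC4CC(C3)N4)nn2)cc1` differs in its core and lacks the methyl group, and in this assay compound 2 gives 441 nM. Compound 1 therefore has the lower of the two numbers, and the gap to compound 2 lies well beyond the usual scatter.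

Compound 3 `Oc1ccc(Nc2cncc(N3CC4CC(C3)N4)c2)cc1` keeps the whole of compound 1 except one small change: hydroxy in place of methyl on an aromatic carbon. For the measured compounds named here, no measured pair shows this exchange, so its effect is not yet known here. The step from compound 1 to compound 3 is expected to be small, probably a modest weakening of no more than a few units of scatter, a 2.4-fold higher number from compound 1 to compound 3 (0.37 log units; beyond the scatter). In this assay compound 3 is estimated to give 0.35 nM, within a range from 0.08 nM to 1.6 nM.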

Compound 3, inhibition constant: 0.342 nM
The estimate for compound 3 lay 1.0-fold (0.01 log units) above the measured number, and the stated range covers the measured number.
By their numbers in this assay, from the lowest: compound 1; then compound 3; then compound 2.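

For the compounds shown here, this pair gives the first direct reading of a change at this position, on the carbon-only aromatic ring and para to a large group. In this assay, putting hydroxy in place of methyl produces a 2.3-fold higher number from compound 1 to compound 3 (0.36 log units; beyond the scatter), a modest step even though hydroxy brings one hydrogen-bond donor and one hydrogen-bond acceptor that methyl lacks. The result shows that the position accepts this exchange with only a modest change in the number, but nothing measured here explains the size of the step.

From the compounds shown here alone, whether an amine, a methoxy group or a carboxylic acid at the same position would stay as close to compound 1 remains open. Going by these compounds, it is also open whether hydroxy at this position would have a similar effect on the core of compound 2.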